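A formyl group in place of compound 3's end group

The source may hold more compounds than are shown below. What is called first, only, known or untested is meant among the compounds shown, and "the series" means these compounds.

Compound 1 `C=C[C@@](C)(/C=C/c1ccc(O)cc1)CCCO`, compound 2 `C=C[C@@](C)(/C=C/c1ccc(O)cc1)CC/C=C/C#N` and compound 3 `C=C[C@@](C)(/C=C/c1ccc(O)cc1)CC/C=C(C)/C=N/N` share one core and differ at the chain end. In an ADME assay on BJ cells (Homo sapiens) for cytotoxicity, with a stated time of 72 h (a lower number here means that less compound is needed, a higher number that more compound is needed for the effect), compound 1 gives > 36600 nM, which is a limit. Compound 2 gives > 36600 nM, also a limit. Compound 3 gives > 36600 nM, again a limit, so it has no number of its own. Compound 4 `C=C[C@@](C)(/C=C/c1ccc(O)cc1)CC/C=C(\C)C=O` differs from it thus: a group of 2 heavy atoms (1 carbon, 1 oxygen; no ring) in place of a group of 3 heavy atoms (1 carbon, 2 nitrogen; no ring), on a double-bonded chain carbon bound to a double-bonded chain carbon and a saturated chain carbon. Three measured changes bear on this, namely a step that the two limits leave unreadable from compound 1 to compound 2, a step that the two limits leave unreadable from compound 1 to compound 3 and a step that the two limits leave unreadable from compound 2 to compound 3, and none offers a size to carry over. The expected result is therefore a number no higher from compound 3 to compound 4 (the limit leaves the size open), with no change expected beyond the scatter. Compound 4 is estimated at 36600 nM, with an expected range from 15000 nM to 60000 nM.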

Compound 4, half-maximal effective concentration: > 36600 nM
Compound 4 ended at the assay's limit; the forecaster's own chance of this, stated with the estimate: 70%; the middle value lies on the limit itself.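

Going by these compounds alone, compound 1, compound 2, compound 3 and compound 4 all stand at a limit in this assay, so no step among them can be read: the limit of > 36600 nM in this assay, at which 4 of the 4 values shown sit.

On these data alone, whether these compounds differ at all in this assay, and by how much, stays open.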